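The source may hold more compounds than are shown below. What is called first, only, known or untested is meant among the compounds shown, and "the series" means these compounds.

Compound 1 `COc1ccc(C(=O)/C=C/c2ccc(-c3ccccc3)cc2)c2c1C=CC(C)(C)O2` is a chalcone-type molecule tested in a functional assay on HepG2 cells (Homo sapiens) for antiproliferative activity, read by MTT assay, with a stated time of 24 h; a higher number here means a weaker inhibitor, a lower number a stronger inhibitor. In this assay compound 1 gives > 10000 nM, which is a limit of the assay rather than a measured number. Compound 2 `COc1ccc(C(=O)/C=C/c2ccc(N(c3ccccc3)c3ccccc3)cc2)c2c1C=CC(C)(C)O2` also gives > 10000 nM in this assay, again only a limit. Among the measured compounds shown here, both reported values sit at the limit of > 10000 nM in this assay, at which 2 of the 2 values shown sit, so no difference between compound 1 and compound 2 can be read from them, and no measured step between any two compounds is available. Compound 3 `COc1ccc(C(=O)/C=C/c2ccccc2)c2c1C=CC(C)(C)O2` has not yet been measured in this assay; it differs from compound 1 by hydrogen in place of phenyl on an aromatic carbon. With both known values resting at a limit, the step from compound 1 to compound 3 is expected to be a step that the limit leaves unreadable from compound 1 to compound 3, small and within the usual scatter. Compound 3 is therefore estimated to give 15000 nM in this assay, within a range from 5000 nM to 50000 nM, and most likely once more only a limit is reported.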

Compound 3, half-maximal inhibitory concentration: > 10000 nM
Compound 3: only a limit was reported (the forecaster's own chance of this, stated with the estimate: 70%); the middle value is on the limit's open side.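

Among the compounds shown here, compound 1 and compound 3 both rest at a limit, so no step between them can be read: the limit of > 10000 nM in this assay, at which 3 of the 3 values shown sit. What the compounds shown leave open is whether swapping phenyl for hydrogen changes activity in this assay at all, and how strongly any of them acts.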